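Morpholine to pyrrolidine on the dithiocarbamate of compound 1

The compounds below may be only part of what the source reports. "The series", "measured", "known", "first", "only" and "open" are said of these compounds alone.

For the measured compounds named here, measured in a functional assay on HEp-2 cells (Homo sapiens) for antiproliferative activity, read by MTT assay, with a stated time of 72 h (on this read-out lower numbers stand for stronger inhibition and higher numbers for weaker inhibition), compound 1 `O=c1c(CSC(=S)N2CCOCC2)coc2cc(Cl)ccc12` gives 900 nM, the lowest of the three numbers so far. Compound 3 `O=c1c(CSC(=S)N2CCOCC2)coc2ccccc12` gives 4400 nM in this assay. Compound 2 `O=c1c(Cl)c(CSC(=S)N2CCOCC2)oc2ccccc12` differs from compound 1 in several places. In this assay compound 2 gives 9000 nM. Going by the values given here, the single one-place step, a 4.9-fold higher number from compound 1 to compound 3 (0.69 log units; beyond the scatter), replaces the chloro on an aromatic carbon with hydrogen and leaves the amine untouched.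

Compound 4 `O=c1c(CSC(=S)N2CCCC2)coc2cc(Cl)ccc12` keeps the chloro and the rest of the core of compound 1 and changes only the amine: pyrrolidin-1-yl in place of morpholin-4-yl on a thiocarbonyl carbon. Among the compounds with values here, no measured step in this set changes the amine on the thiocarbonyl carbon, so the step from compound 1 to compound 3 does not bear on it, and there is nothing to set a direction from. The expectation is therefore no step beyond the scatter, no change at the digits printed from compound 1 to compound 4 (within the scatter), and compound 4 is estimated at 900 nM in this assay, within 300 nM to 3000 nM.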

Compound 4, half-maximal inhibitory concentration: 2100 nM
Compound 4: the middle estimate sits 2.3-fold (0.37 log units) below what was measured, and the stated range covers the measured number.
By their numbers in this assay, from the lowest: compound 1; then compound 4; then compound 3; then compound 2.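

Read in this assay the amine on the thiocarbonyl carbon now counts as a position that moves the number, with a 2.3-fold higher number from compound 1 to compound 4 (0.37 log units; beyond the scatter) for pyrrolidin-1-yl in place of morpholin-4-yl while the chloro and the rest of the core stay fixed. For the compounds shown here, until this result the only one-place step lay on the aromatic carbon, with a 4.9-fold higher number from compound 1 to compound 3 (0.69 log units; beyond the scatter) for hydrogen in place of chloro, so a second site of change now has a step beyond the scatter, and of the two amines compared on this core morpholin-4-yl gives the lower number. No measurement at hand bears on the reason for the amine step.

From the compounds shown here alone, whether the same amine change carries over to the core of compound 3 remains open. So does where a piperidin-1-yl or dimethylamino group on the thiocarbonyl carbon would fall relative to compound 1 and compound 4.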